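Replacing pyridin-2-yl with 3-hydroxyphenyl: what to expect

The source may hold more compounds than are shown below. What is called first, only, known or untested is meant among the compounds shown, and "the series" means these compounds.

Measured so far:
compound 1, `OCCCCC#Cc1ccccc1C#Cc1ccccn1`: 26100 nM
compound 2, `CSc1ccccc1C#Cc1ccccc1C#CCCCCO`: 14700 nM
compound 3, `OCCCCC#Cc1ccccc1C#Cc1ccccc1C(F)(F)F`: 2300 nM

In a functional assay on OVCAR-3 cells (Homo sapiens) for cytotoxicity (a lower number here means a stronger inhibitor of growth, a higher number a weaker inhibitor of growth), compound 1 gives 26100 nM, the highest of the three numbers. Compound 2 gives 14700 nM in this assay, which lies within the scatter of compound 1, so no order between the two can be claimed. Compound 3 gives 2300 nM in this assay, clearly lower than compound 1.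

Within the data shown here, the only step measured between two compounds that differ in one place is a 6.4-fold lower number from compound 2 to compound 3 (0.81 log units; beyond the scatter). That step swaps one group for another on a carbon-only ring and says nothing direct about exchanging a ring that carries a nitrogen for one that carries a hydroxyl.

Compound 4, `OCCCCC#Cc1ccccc1C#Cc1cccc(O)c1`, differs from compound 1 in exactly that way: 3-hydroxyphenyl in place of pyridin-2-yl on a triple-bonded carbon. Among the measured compounds shown here, with no measured step that bears on this change, the expectation for compound 4 in this assay is set close to compound 1, with a wide range, and the step expected is a 1.5-fold lower number from compound 1 to compound 4 (0.16 log units; within the scatter). The estimate for compound 4 in this assay is 18000 nM, between 5000 nM and 60000 nM.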

Compound 4, concentration for 50% growth inhibition: 20000 nM
Compound 4: the middle estimate sits 1.1-fold (0.05 log units) below what was measured; measured number inside the range.
By their numbers in this assay, from the lowest: compound 3; then compounds 2, 4 and 1 (each within the scatter of the next).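

In this assay, putting 3-hydroxyphenyl in place of pyridin-2-yl on a triple-bonded carbon gives a 1.3-fold lower number from compound 1 to compound 4 (0.12 log units; within the scatter), so no order can be claimed between the two compounds. Among these compounds, this is the first direct reading of a ring exchange at this position: a ring with a nitrogen gives way to a ring of carbon only, a hydrogen-bond donor enters, and the number in this assay does not shift measurably. No measurement is available that could explain this outcome.

What remains open is whether the hydroxyl contributes anything by itself, since a comparison with plain phenyl on the same triple-bonded carbon is not among the compounds shown, and neither is a comparison with an amine or a carboxylic acid on that ring. As far as these compounds go, it also remains open whether a single exchange on this ring can reach the level of compound 3 at 2300 nM when the shared core and its hydroxyl-ending chain stay the same, or whether a longer chain would alter the picture.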